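Chlorophenyl for Benzyl on the Triazole Nitrogen

The compounds below may be only part of what the source reports. "The series", "measured", "known", "first", "only" and "open" are said of these compounds alone.

Compound 2 `CCCCCCC#Cc1c(CCCCCC)oc2nc(=O)n(Cc3cn(Cc4ccccc4)nn3)cc12` and compound 1 `CCCCCCC#Cc1c(CCCCCC)oc2nc(=O)n(Cc3cn(-c4ccc(Cl)cc4)nn3)cc12` share one core and differ in a single place, namely (4-chlorophenyl in place of benzyl on an aromatic nitrogen). In a functional assay on HeLa cells (Homo sapiens) for antiproliferative activity, read by MTT assay, with a stated time of 72 h (on this read-out lower numbers stand for stronger inhibition and higher numbers for weaker inhibition), compound 2 gives 23400 nM. Compound 1 reaches only a limit of the assay, recorded as > 100000 nM. What is known of that step is bounded by the limit of > 100000 nM in this assay, at which 1 of the 3 values shown sits, and reads an at least 4.2-fold higher number from compound 2 to compound 1 (0.63 log units; beyond the scatter). Compound 3 `O=c1nc2oc(CCCCl)cc2cn1Cc1cn(Cc2ccccc2)nn1` rests on another core; how its core differs from that of compound 2 is not broken down here. In this assay compound 3 gives 9580 nM, the lower of the two numbers. Compound 4 `O=c1nc2oc(CCCCl)cc2cn1Cc1cn(-c2ccc(Cl)cc2)nn1` has not yet been measured and differs from compound 3 by 4-chlorophenyl in place of benzyl on an aromatic nitrogen, the same change as from compound 2 to compound 1. Because an at least 4.2-fold higher number from compound 2 to compound 1 (0.63 log units; beyond the scatter) was seen, the expected step is a 5.2-fold higher number from compound 3 to compound 4 (0.72 log units; beyond the scatter), and the estimate may again end at a limit. Compound 4 is thus expected to give 50000 nM, with an expected range from 20000 nM to 200000 nM.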

Compound 4, half-maximal inhibitory concentration: 60200 nM
Estimate against measurement, compound 4: 1.2-fold (0.08 log units) below; the measured number falls inside the stated range.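

In this assay the change to 4-chlorophenyl in place of benzyl on an aromatic nitrogen gives a 6.3-fold higher number from compound 3 to compound 4 (0.80 log units; beyond the scatter) and so weakens inhibition on this second core as well. Both pairs therefore move the same way, which shows that the direction of the change carried over between these two cores: the same change on two cores in this assay, an at least 4.2-fold higher number (0.63 log units; beyond the scatter) from compound 2 to compound 1 and a 6.3-fold higher number (0.80 log units; beyond the scatter) from compound 3 to compound 4; the limit leaves it open whether they differ. Its size cannot be compared, and two cores do not show that the change would carry to others, as compound 1 is recorded only as a limit: the limit of > 100000 nM in this assay, at which 1 of the 4 values shown sits.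

The compounds shown leave open whether the step comes from the chlorine or from losing the methylene link, which a plain phenyl on the same nitrogen would separate. Going by these compounds, how a 4-methoxyphenyl or a pyridyl group would read there also remains open.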